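Hydroxyl Position Against Trifluoromethoxy Placement in Four Compounds

The source may hold more compounds than are shown below. What is called first, only, known or untested is meant among the compounds shown, and "the series" means these compounds.

Compound 1 `O=C(/C=C/c1ccccc1OC(F)(F)F)c1cccc(O)c1` and compound 2 `O=C(/C=C/c1ccccc1OC(F)(F)F)c1ccc(O)cc1` differ only at the carbonyl carbon. In a functional assay on RAW264.7 cells (Mus musculus) for inhibition, read by fluorescence, with stated times of 1 h, 24 h and 30 min (a lower number here means a stronger inhibitor, a higher number a weaker inhibitor), compound 1 gives 1610 nM and compound 2 gives 1340 nM. That change, (4-hydroxyphenyl in place of 3-hydroxyphenyl on a carbonyl carbon), is measured as a 1.2-fold lower number from compound 1 to compound 2 (0.08 log units; within the scatter). Compound 3 `O=C(/C=C/c1cccc(OC(F)(F)F)c1)c1cccc(O)c1` carries the trifluoromethoxy group on another ring position; the difference between its core and that of compound 1 is not broken down here. In this assay compound 3 reaches only a limit, > 10000 nM, which is the limit of > 10000 nM in this assay, at which 1 of the 3 values shown sits. Compound 4 `O=C(/C=C/c1cccc(OC(F)(F)F)c1)c1ccc(O)cc1` differs from compound 3 by 4-hydroxyphenyl in place of 3-hydroxyphenyl on a carbonyl carbon, the same change at the same place as from compound 1 to compound 2. The step is expected to be a number no higher from compound 3 to compound 4 (the limit leaves the size open), resting on the earlier step having been a 1.2-fold lower number from compound 1 to compound 2 (0.08 log units; within the scatter). Compound 4 is therefore estimated at 10000 nM, probably between 4000 nM and 30000 nM, and may itself return only a limit.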

Compound 4, half-maximal inhibitory concentration: > 10000 nM
Compound 4: only a limit was reported; the forecaster's own chance of this, stated with the estimate: 65%; the middle value sits exactly at the limit.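

In this assay compound 3 and compound 4 both stand at a limit, and the step between them cannot be read: the limit of > 10000 nM in this assay, at which 2 of the 4 values shown sit. On these data alone, what stays open is whether 4-hydroxyphenyl in place of 3-hydroxyphenyl changes anything on the core of compound 3.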